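The source may hold more compounds than are shown below. What is called first, only, known or untested is meant among the compounds shown, and "the series" means these compounds.

Measured so far:
Compound 1, `CC1=C(C(=O)OC(C)C)C(c2ccoc2)NC(=O)N1C`: 37%
Compound 2, `CC1=C(C(=O)OC(C)(C)C)C(c2ccoc2)NC(=O)N1C`: 16%
Compound 3, `CCSC(=O)C1=C(C)NC(=O)NC1c1ccco1`: 29%

All three were tested in an assay on membranes from HEK293 cells for displacement of a labelled ligand from adenosine receptor A2b (Homo sapiens), read by scintillation counting, with a stated time of 30 min, tested at 1 uM; a lower number here means less inhibition, a higher number more inhibition at the concentration tested (going by the name of the read-out). Compound 1 and compound 2 share one core and differ in a single place, (methyl in place of hydrogen on a saturated chain carbon bound to an oxygen next to a carbonyl group and two saturated chain carbons). That change gave a number 21 percentage points lower from compound 1 to compound 2 (beyond the scatter). Compound 3 sits on a different core; how the two cores differ is not broken down here. Its value lies within the scatter of compound 1 and beyond the scatter of compound 2.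

Compound 4, `CC1=C(C(=O)SC(C)C)C(c2ccco2)NC(=O)N1`, is not yet measured. It differs from compound 3 in one place, (methyl in place of hydrogen on a saturated chain carbon bound to a saturated chain carbon and a sulfur). For the measured compounds named here, this is the same kind of change as the one from compound 1 to compound 2, but the surroundings differ: there the carbon was bound to an oxygen next to a carbonyl group and two saturated chain carbons, here it is bound to a saturated chain carbon and a sulfur. Resting on the step from compound 1 to compound 2 in this assay, which was a number 21 percentage points lower from compound 1 to compound 2 (beyond the scatter), a drop is expected for compound 4 too, though a somewhat smaller one, since the added methyl here enlarges a shorter chain. The step from compound 3 to compound 4 is therefore estimated at a number 11 percentage points lower from compound 3 to compound 4 (beyond the scatter). Compound 4 is expected to give about 18%, with a likely range from 5% to 32%.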

Compound 4, a percentage reported as inhibition, at one concentration (the size of the read-out at that concentration, not a potency): 22%
Beside the measured number, compound 4's estimate is 4 percentage points below it; the range from low to high includes it.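

Replacing ethylsulfanyl with isopropylsulfanyl in the thioester of compound 3 gave a number 7 percentage points lower from compound 3 to compound 4 (within the scatter) in this assay, so on this core the added methyl produced no change that can be separated from ordinary variation between repeated measurements. Set beside the same change on the other core, the two steps cannot be told apart: the same change on two cores in this assay, a number 21 percentage points lower (beyond the scatter) from compound 1 to compound 2 and a number 7 percentage points lower (within the scatter) from compound 3 to compound 4, 14 percentage points apart, within the scatter of two such steps This fits the idea that the change carries from one core to the other, but it does not establish it, since each core offers only one pair and the step on the second core cannot itself be distinguished from no effect.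

The compounds shown leave open how the number would respond to a longer chain such as n-butyl in this position, or to a chain ending in an amine or a carboxylic acid. For the compounds shown here, they also leave open whether the same change would give a similar step on other cores, as only two cores appear here.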